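The source may report more compounds than this note shows. Statements on the series, on what has been measured and on what is new or still open speak of the compounds shown alone.

Measured in an ADME assay on microsomes from liver (Homo sapiens) for metabolic stability; a lower number here means that the compound disappears faster, a higher number that the compound lasts longer:
- compound 1 `CC(C)C(c1ccc(-c2ccc3cccc(F)c3c2)[nH]c1=O)N1CCCCS1(=O)=O`: 0.373 h
- compound 2 `CC(C)C(Nc1nnc[nH]1)c1ccc(-c2ccc3cccc(F)c3c2)[nH]c1=O`: > 3 h (a limit of the assay)
- compound 3 `CC(C)C(c1ncc[nH]1)c1ccc(-c2ccc3cccc(F)c3c2)[nH]c1=O`: < 0.0667 h (a limit of the assay)

Compound 3 stands lowest of the three, and its value is a limit rather than a number. The gaps are an at least 5.5-fold lower number from compound 1 to compound 3 (0.74 log units; beyond the scatter) and an at least 44-fold lower number from compound 2 to compound 3 (1.65 log units; beyond the scatter), both beyond the scatter, the second large.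

Compound 4 `CC(C)C(c1noc(=O)[nH]1)c1ccc(-c2ccc3cccc(F)c3c2)[nH]c1=O` differs from compound 3 by a group of 6 heavy atoms (2 carbon, 2 nitrogen, 2 oxygen; one five-membered aromatic ring with 3 hetero atoms) in place of a group of 5 heavy atoms (3 carbon, 2 nitrogen; one five-membered aromatic ring with 2 hetero atoms), on a saturated chain carbon bound to an aromatic carbon and a saturated chain carbon. The change sits on a saturated chain carbon bound to an aromatic carbon and a saturated chain carbon. The entering group is a five-membered aromatic ring with 3 hetero atoms, as in compound 2, although compound 2 carries its ring as (4H-1,2,4-triazol-3-yl)amino. The closest guide is therefore the large step of an at least 44-fold lower number from compound 2 to compound 3 (1.65 log units; beyond the scatter), with an at least 8.0-fold higher number from compound 1 to compound 2 (0.90 log units; beyond the scatter) as further support. Both are bounds, so they fix a direction better than a size.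

In this assay a clear rise beyond the scatter is expected, stated as an at least 17-fold higher number from compound 3 to compound 4 (1.25 log units; beyond the scatter). For compound 4 the estimate is 1.2 h, with an expected range of 0.3 h to 3 h.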

Compound 4, half-life: > 3 h
Compound 4 was reported as a limit (the forecaster's own chance of this, stated with the estimate: 35%); at least 2.5-fold (0.39 log units) between middle value and limit.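

On a saturated chain carbon bound to an aromatic carbon and a saturated chain carbon, a five-membered aromatic ring without an amino link can still give a long half-life in this assay, so compound 3 does not speak for all such rings. The gain over the imidazole is an at least 44-fold higher number from compound 3 to compound 4 (1.65 log units; beyond the scatter), and the gain over the cyclic sulfonamide of compound 1 is an at least 8.0-fold higher number from compound 1 to compound 4 (0.90 log units; beyond the scatter). Compound 2 and compound 4 both stand at the upper limit of the assay, so the step between them cannot be read: the limit of > 3 h in this assay, at which 2 of the 4 values shown sit.

Compound 3 and compound 4 differ in several ring atoms at once, which leaves open whether the ring carbonyl, the ring oxygen or the extra hetero atom carries the rise. Going by these compounds, how a carboxylic acid or a primary amine would behave on the same carbon also stays open.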